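The compounds below may be only part of what the source reports. "The series", "measured", "known", "first", "only" and "open" are said of these compounds alone.

The study concerns an ADME assay on cells for inhibition of cytochrome P450 11B1, mitochondrial (Homo sapiens), read by HTRF (a higher number here means a weaker inhibitor, a lower number a stronger inhibitor), and three compounds have been measured in it. Compound 1, `CCC(=O)N[C@@H]1CCCc2c1cncc2N1Cc2cc(Cl)ccc2C1=O`, gives 5210 nM. Compound 2, `N#Cc1ccc2c(c1)CN(c1cccnc1)C2=O`, gives 15500 nM. Within the data shown here, compound 3, `O=C(Nc1cccnc1)c1ccc(Cl)cc1`, returns only a limit of the assay, > 3000 nM, not a number; it is the single value sitting at the limit of > 3000 nM in this assay, at which 1 of the 3 values shown sits.

Among the two numbers that are known, compound 2 stands highest: its neighbour is compound 1, whose number is lower by an amount beyond the usual scatter of repeated measurements, so compound 2 is the weaker inhibitor of the two.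

The step under consideration leads from compound 2 to compound 4, `O=C1c2ccccc2CN1c1cccnc1`, not yet measured in this assay. The change is hydrogen in place of cyano on an aromatic carbon.

Among the measured compounds shown here, no pair of measured compounds differs in one place, so no measured step offers a reference for this change. The cyano group is a small substituent on the fused six-membered carbon ring, and compound 2 already lies at the weak end of the known numbers. Compound 4 is therefore expected to stay close to compound 2, with a step of a 1.3-fold higher number from compound 2 to compound 4 (0.11 log units; within the scatter) that need not exceed the scatter in either direction. The estimate for compound 4 is 20000 nM, with a range from 6000 nM to 60000 nM.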

Compound 4, half-maximal inhibitory concentration: > 3000 nM
Compound 4 ended at the assay's limit; the forecaster's own chance of this, stated with the estimate: 25%; the middle value is on the limit's open side.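

In this assay, among these compounds, compound 4 returns only a limit of the assay, > 3000 nM, so no step from compound 2 to compound 4 can be read. Compound 3 also sits there: the limit of > 3000 nM in this assay, at which 2 of the 4 values shown sit.

The compounds shown leave open whether hydrogen in place of cyano makes compound 4 a stronger or a weaker inhibitor than compound 2.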